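The source may report more compounds than this note shows. Statements on the series, on what has been measured and on what is new or still open speak of the compounds shown alone.

Compound 1, `CC1=CC[C@H](C(C)(C)NC(=S)N/N=C/c2ccccc2O)CC1`, gives < 40 nM in a functional assay on PC-3 cells (Homo sapiens) for inhibition, read by sulforhodamine B assay, with a stated time of 48 h; on this read-out lower numbers stand for stronger inhibition of growth and higher numbers for weaker inhibition of growth; that value is a limit of the assay, not a number.
Compound 2, `CC1=CC[C@H](C(C)(C)NC(=S)N/N=C/c2ccccc2Cl)CC1`, gives 50 nM in this assay.

Going by the values given here, compound 2 therefore stands as the only compound with a measured number; the other value shown is a limit, as recorded in the limit of < 40 nM in this assay, at which 1 of the 2 values shown sits. Among the compounds with values here, the single measured step, an at least 1.2-fold higher number from compound 1 to compound 2 (0.09 log units; that floor lies within the scatter), is too small to separate the two compounds from each other.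

Compound 3, `CC1=CC[C@H](C(C)(C)NC(=S)N/N=C/c2ccc[nH]2)CC1`, differs from compound 2 by 1H-pyrrol-2-yl in place of 2-chlorophenyl on a carbon with a double bond to nitrogen. Within the data shown here, no measured step covers a change of this kind, and the one step that is known, from compound 1 to compound 2, stayed within the scatter. The expectation for compound 3 is therefore a step of a 1.4-fold higher number from compound 2 to compound 3 (0.15 log units; within the scatter), not clearly beyond the scatter. The estimate for compound 3 in this assay is 70 nM, with a range from 25 nM to 200 nM.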

Compound 3, concentration for 50% growth inhibition: 2800 nM
Compound 3: the middle estimate sits 40-fold (1.60 log units) below what was measured; measured number outside the range, above it.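

The earlier swap of hydroxy and chloro on the phenyl ring left compound 1 and compound 2 inseparable, but this position does not accept every ring: in this assay, 1H-pyrrol-2-yl in place of 2-chlorophenyl on the carbon with a double bond to nitrogen gives a 56-fold higher number from compound 2 to compound 3 (1.75 log units; beyond the scatter). The same exchange starting from 2-hydroxyphenyl gives an at least 70-fold higher number from compound 1 to compound 3 (1.84 log units; beyond the scatter), so both substituted phenyl groups stand far from the pyrrole on this read-out. The value of compound 1 is a limit and not a number, which makes that second step a floor: the limit of < 40 nM in this assay, at which 1 of the 3 values shown sits.

The change swaps a six-membered ring for a five-membered one and adds a hydrogen-bond donor in a single move, so the compounds shown cannot tell which of these matters. Also open, on these data alone, is how an unsubstituted phenyl or a furan-2-yl group would fare here.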